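Trimming the Amine Substituent in a Brominated Diaryl Ether Series

A few compounds are considered here, and "the series" means these few. Any claim that something is new, unique, unknown or untested is made for them only; others in the source may bear on it.

Measured compounds:
- compound 1, `CC(C)(C)OC(=O)N1CCCN(CCCCCOc2c(Br)cc(Br)cc2Oc2ccc(Br)cc2Br)CC1`: 44.8 ug/mL
- compound 2, `Brc1ccc(Oc2cc(Br)cc(Br)c2OCCCCCN2CCN(C/C=C/c3ccccc3)CC2)c(Br)c1`: 47.2 ug/mL
- compound 3, `CC(=O)Oc1c(Br)cc(Br)cc1Oc1ccc(Br)cc1Br`: 29.9 ug/mL

All three were tested in a functional assay on HL-60 cells (Homo sapiens) for cytotoxicity, read by MTT assay, with a stated time of 24 h; on this read-out higher numbers stand for weaker inhibition and lower numbers for stronger inhibition. Compound 1 gives 44.8 ug/mL in this assay, compound 2 gives 47.2 ug/mL, and compound 3 gives 29.9 ug/mL. Compound 2 shows the largest number of the three, but its gap to compound 1 and its gap to compound 3 both lie within the usual scatter of this kind of measurement, so the three numbers are best read as alike rather than ranked.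

Compound 4, `CN1CCN(CCCCCOc2c(Br)cc(Br)cc2Oc2ccc(Br)cc2Br)CC1`, has not yet been measured. It differs from compound 2 in one place: hydrogen in place of 2-phenylethenyl on a saturated chain carbon bound to an amine nitrogen in a ring

The three measured compounds carry quite different groups on the far end of the chain, or no chain at all, and still land close together. Within the data shown here, no measured pair tracks this particular change, so nothing is known about its size here. The expectation is that the step of a 1.0-fold lower number from compound 2 to compound 4 (0.02 log units; within the scatter) stays within the scatter, with no clear direction. Compound 4 is therefore estimated at 45 ug/mL in this assay, with a likely range from 22 ug/mL to 90 ug/mL.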

Compound 4, half-maximal inhibitory concentration: 48.3 ug/mL
The estimate for compound 4 lay 1.1-fold (0.03 log units) below the measured number; the range from low to high includes it.
By their numbers in this assay, from the lowest: compounds 3, 1, 2 and 4 (each within the scatter of the next).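

In this assay, putting hydrogen in place of 2-phenylethenyl on a saturated chain carbon bound to an amine nitrogen in a ring gives a 1.0-fold higher number from compound 2 to compound 4 (0.01 log units; within the scatter), so this change leaves no mark that can be told from the scatter. Compounds 1, 2 and 3 differ from one another in more than one place, so they could not isolate any single change, whereas this pair shows that a group of 8 heavy atoms, with a six-membered aromatic ring and a double bond, can be cut back to methyl on the ring amine without a readable shift in this cell assay. No measurement at hand offers an explanation for this lack of response.

The compounds shown leave open whether a different kind of group at this place, such as a carboxylic acid or a primary amine, would move the number beyond the scatter. They also leave open whether a longer chain carrying the ring amine would do so, and whether any such change could give a clearly stronger compound.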